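Triazole to imidazole swap: cytotoxicity notes

The source may hold more compounds than are shown below. What is called first, only, known or untested is meant among the compounds shown, and "the series" means these compounds.

Measured in an ADME assay on Vero cells (Chlorocebus sabaeus) for cytotoxicity, read by resazurin assay, with a stated time of 72 h; a higher number here means that more compound is tolerated, a lower number that less compound is tolerated:
- compound 1 `CCCCC1(CCCC)C[C@@H](CNCCCn2cncn2)[C@@](C)(OC)OO1`: "not determined" (no result reported)
- compound 2 `CO[C@]1(C)OOC2(CC[C@H]3C[C@@H]2C3(C)C)C[C@H]1CNCCCn1ccnc1`: 300000 nM; 277000 nM (2 entries)

Compound 1 has no number in this assay, so it offers no baseline. Compound 3 `CCCCC1(CCCC)C[C@@H](CNCCCn2ccnc2)[C@@](C)(OC)OO1` is not yet measured. It carries 1H-imidazol-1-yl in place of 1H-1,2,4-triazol-1-yl on a saturated chain carbon, three bonds along the chain from an amine nitrogen. No measured step sizes this change, so no shift beyond the scatter is expected in this assay, and no direction is assumed. Going by the values given here, the only numbers available are those of compound 2 (the several entries of compound 2 in this assay, 300000 nM; 277000 nM (2 entries)), which anchor the expectation. For compound 3 the expected value is 200000 nM, with an estimated range of 70000 nM to 400000 nM.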

Compound 3, half-maximal cytotoxic concentration: 74500 nM
The estimate for compound 3 lay 2.7-fold (0.43 log units) above the measured number, and the stated range covers the measured number.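

In this assay, going by these compounds alone, compound 1 stands as "not determined" (no result reported), so no step to compound 3 at 74500 nM can be read. From the compounds shown here alone, what 1H-imidazol-1-yl in place of 1H-1,2,4-triazol-1-yl does to tolerance on this core remains open.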